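This account rests on a few compounds, and the source may have more. Where it says the series, first, only, none or still open, it means among the compounds named here.

Among the measured compounds shown here, compound 2, `COc1ccc(C(=O)c2sc(Nc3ccc(F)cc3)c(C(=O)O)c2C)cc1`, is the only member of this small set for which a number is given: in a functional assay, with a stated time of 150 min, tested at 20 ug/mL (a lower number here means a weaker effect, a higher number a stronger effect of the compound at the concentration tested), compound 2 gives 3.58%, a weak effect. Its two relatives carry no number at all. Compound 1, `COC(=O)c1c(Nc2ccc(F)cc2)sc(C(=O)c2ccc(C)cc2)c1C`, is reported in this assay as "not active" (no number reported), and compound 3, `COc1ccc(C(=O)c2sc(Nc3ccc(Cl)cc3)c(C(=O)O)c2C)cc1`, is likewise reported in this assay as "not active" (no number reported). Compound 4, `Cc1ccc(C(=O)c2sc(Nc3ccc(F)cc3)c(C(=O)O)c2C)cc1`, has not been measured. It differs from compound 2 in one place: methyl in place of methoxy on an aromatic carbon. For the measured compounds named here, with only one number to lean on, the expected step of a number 0.6 percentage points lower from compound 2 to compound 4 (within the scatter) in this assay is taken to stay within the scatter, in no clear direction. Compound 4 is therefore estimated at 3%, within 0% to 12%.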

Compound 4, a percentage reported as activity, at one concentration (the size of the read-out at that concentration, not a potency): "not active" (no number reported)
No number was reported for compound 4; the estimate stays without a comparison.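

Among the compounds shown here, compound 4 is reported without a number, so no step from compound 2 to it can be read in this assay. The compounds shown leave open how 4-methoxyphenyl and 4-methylphenyl compare in this read-out. No measured evidence bears on this result.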